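The source may hold more compounds than are shown below. What is called first, only, known or untested is meant among the compounds shown, and "the series" means these compounds.

Compound 1, `FC(F)(F)c1ccc(COc2cccc(Nc3ncnc4cc5c(cc34)OCCOCCOCCO5)c2)cc1`, gives 20000 nM in a functional assay on SH-SY5Y cells (Homo sapiens) for antiproliferative activity, read by MTT assay, with a stated time of 72 h; on this read-out higher numbers stand for weaker inhibition and lower numbers for stronger inhibition. Compound 2, `O=[N+]([O-])c1ccc(COc2ccccc2Nc2ncnc3cc4c(cc23)OCCOCCOCCO4)cc1`, gives 75500 nM in this assay. Compound 3, `FC(F)(F)c1ccc(COc2ccc(Nc3ncnc4cc5c(cc34)OCCOCCOCCOCCO5)cc2)cc1`, gives 2140 nM in this assay.

Compound 2 stands at the highest of the three numbers, which on this read-out means the weakest inhibition. Its nearest neighbour is compound 1, whose number lies lower by a margin beyond the usual scatter; compound 3 lies furthest below it, again beyond the scatter. The three compounds share a core, and they differ from one another in more than one place, so none of these gaps can be tied to a single structural change.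

Compound 4, `c1ccc(COc2ccccc2Nc2ncnc3cc4c(cc23)OCCOCCOCCO4)cc1`, has not yet been measured in this assay. It differs from compound 2 in one place: hydrogen in place of nitro on an aromatic carbon. Within the data shown here, no measured pair in this set shows the same change, so its effect cannot be read from a measured step. The expected step is a 1.3-fold lower number from compound 2 to compound 4 (0.10 log units; within the scatter), judged small enough to fall within the scatter, with its direction left open. For compound 4 the estimated value in this assay is 60000 nM, with an expected range from 15000 nM to 200000 nM.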

Compound 4, half-maximal inhibitory concentration: 98400 nM
Compound 4: the middle estimate sits 1.6-fold (0.21 log units) below what was measured; low and high end bracket the measured number.
By their numbers in this assay, from the lowest: compound 3; then compound 1; then compounds 2 and 4 (each within the scatter of the next).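

Among these compounds, the change from 4-nitrobenzyl to benzyl is the first step in this set that can be read at a single place, and in this assay it gives a 1.3-fold higher number from compound 2 to compound 4 (0.12 log units; within the scatter). With the rest of the structure held fixed, the two compounds cannot be told apart in this assay, even though a nitro group of 3 heavy atoms gives way to a hydrogen atom on an aromatic carbon, para to a large group. The nitro group at this place is therefore not required for the activity seen with compound 2, something that compounds 1 and 3 could not show, as they differ from compound 2 in more than one place.

Nothing given here bears on the reason for this result. From the compounds shown here alone, it remains open whether an amino group, a methoxy group or a carboxylic acid at the same carbon would also stay within the scatter, and whether hydrogen in place of nitro would read the same way on the scaffold of compound 1 or compound 3.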